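Compound 2 takes on a 4-(hydroxycarbamoyl)benzyl group

This account rests on a few compounds, and the source may have more. Where it says the series, first, only, none or still open, it means among the compounds named here.

In a functional assay on PC-3 cells (Homo sapiens) for inhibition, read by sulforhodamine B assay, with a stated time of 48 h (on this read-out lower numbers stand for stronger inhibition and higher numbers for weaker inhibition), compound 1 `O=C(Nc1ccc2c(c1)N(Cc1ccc(C(=O)NO)cc1)CC2)Nc1ccc(Cl)c(C(F)(F)F)c1` gives 3100 nM. Compound 2 `O=C(Nc1ccc(Nc2ncc(C(=O)NO)cn2)cc1)Nc1ccc(Cl)c(C(F)(F)F)c1` gives > 10000 nM, which is a limit of the assay and not a number, and it stands at the limit of > 10000 nM in this assay, at which 1 of the 2 values shown sits. Compound 3 `O=C(Nc1ccc(NCc2ccc(C(=O)NO)cc2)cc1)Nc1ccc(Cl)c(C(F)(F)F)c1` carries 4-(hydroxycarbamoyl)benzyl in place of 5-(hydroxycarbamoyl)pyrimidin-2-yl on a nitrogen on an aromatic ring. Compound 1 also carries 4-(hydroxycarbamoyl)benzyl and gives 3100 nM, so a modest gain in this assay is expected for compound 3. The expected change is an at least 2.5-fold lower number from compound 2 to compound 3 (0.39 log units; beyond the scatter). For compound 3 the estimated value is 4000 nM, with an expected range of 1200 nM to 10000 nM.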

Compound 3, half-maximal inhibitory concentration: 3800 nM
Estimate against measurement, compound 3: 1.1-fold (0.02 log units) above; low and high end bracket the measured number.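

In this assay, among these compounds, putting 4-(hydroxycarbamoyl)benzyl in place of 5-(hydroxycarbamoyl)pyrimidin-2-yl on a nitrogen on an aromatic ring gives an at least 2.6-fold lower number from compound 2 to compound 3 (0.42 log units; beyond the scatter), the first step that can be read at this position. Compound 2 gives > 10000 nM, a limit of the assay and not a number, so the true size of the step remains unknown: the limit of > 10000 nM in this assay, at which 1 of the 3 values shown sits.

The step changes the ring and its attachment together, and the compounds shown do not separate the two. From the compounds shown here alone, whether a 4-carboxybenzyl group or a longer chain on that nitrogen would keep the gain also stays open.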